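Branching the butyl chain of compound 2

A few compounds are considered here, and "the series" means these few. Any claim that something is new, unique, unknown or untested is made for them only; others in the source may bear on it.

Compound 2, `CCCCn1cnc2c(SCc3ccccn3)nc(N)nc21`, is the lower of the two numbers measured in an assay on isolated protein for binding affinity to Equilibrative nucleoside transporter 1 (Homo sapiens); on this read-out lower numbers stand for stronger inhibition and higher numbers for weaker inhibition: compound 2 gives 52500 nM, while compound 1, `CCCCn1cnc2c(SC(C)C)nc(N)nc21`, gives 120000 nM. Within the data shown here, the one step measured, a 2.3-fold lower number from compound 1 to compound 2 (0.36 log units; beyond the scatter), comes from putting (pyridin-2-yl)methyl in place of isopropyl on a sulfur and is modest in size.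

Compound 3, `CCCC(C)n1cnc2c(SCc3ccccn3)nc(N)nc21`, differs from compound 2 only at the chain on the aromatic nitrogen: methyl in place of hydrogen on a saturated chain carbon bound to an aromatic nitrogen and a saturated chain carbon; cut one bond further out, the same change reads butyl to 1-methylbutyl. Among the measured compounds shown here, no measured step touches this part of the shared core, so the only step available, from compound 1 to compound 2, bears on it indirectly at best and gives no direction. On that basis compound 3 is expected to stay close to compound 2 in this assay, with an expected step of a 1.2-fold lower number from compound 2 to compound 3 (0.07 log units; within the scatter), not clearly beyond the scatter either way. The estimate for compound 3 in this assay is 45000 nM, within a range from 15000 nM to 150000 nM.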

Compound 3, half-maximal inhibitory concentration: 41700 nM
Compound 3: the middle estimate sits 1.1-fold (0.03 log units) above what was measured; the range from low to high includes it.
By their numbers in this assay, from the lowest: compounds 3 and 2 (each within the scatter of the next); then compound 1.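

In this assay, among these compounds, the step of a 1.3-fold lower number from compound 2 to compound 3 (0.10 log units; within the scatter) is the first measured at the chain on the aromatic nitrogen, whereas the only earlier step concerned the group on the sulfur. It shows that, with (pyridin-2-yl)methyl held on the sulfur, butyl and 1-methylbutyl cannot be told apart in this read-out, so a methyl on this saturated chain carbon gives no step beyond the scatter. No available evidence bears on this result.

The compounds shown leave open whether a larger group at this position, such as a longer chain like 1-ethylbutyl, a cyclopentyl ring or a chain ending in an amine, would move the number beyond the scatter in either direction. They also leave open whether the same methyl would behave in the same way with isopropyl on the sulfur, and whether the two mirror-image forms of the 1-methylbutyl group would give different numbers.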